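This account rests on a few compounds, and the source may have more. Where it says the series, first, only, none or still open, it means among the compounds named here.

Measured in a functional assay on MCF7 cells (Homo sapiens) for antiproliferative activity, read by MTT assay, with a stated time of 48 h; a higher number here means a weaker inhibitor, a lower number a stronger inhibitor:
- Compound 1 `COc1ccc2[nH]c(-c3cn(-c4ccccc4)nc3-c3ccc(F)cc3)nc2c1`: 970 nM
- Compound 2 `Fc1ccc2[nH]c(-c3cn(-c4ccccc4)nc3-c3ccc(Cl)cc3)nc2c1`: 2830 nM
- Compound 3 `Clc1ccc(-c2nn(-c3ccccc3)cc2-c2nc3cc(Cl)ccc3[nH]2)cc1`: 1170 nM

The values of compound 3 and compound 1 cannot be told apart within the usual scatter of repeated measurements, while compound 2 has a clearly higher number than both. The next compound, compound 4 `COc1ccc2[nH]c(-c3cn(-c4ccccc4)nc3-c3ccc(Cl)cc3)nc2c1`, has methoxy in place of chloro on an aromatic carbon.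

Among the compounds with values here, only one measured step involves that same carbon: a 2.4-fold lower number from compound 2 to compound 3 (0.38 log units; beyond the scatter). This step is modest and shows that a change at this carbon can move the number, but it does not involve methoxy. Within the data shown here, compound 1 is the only measured compound with a methoxy, and it gives 970 nM. Among the measured compounds shown here, no measured pair compares methoxy directly with chloro.

No step beyond the scatter is therefore expected in this assay, and the estimated step is a 1.2-fold lower number from compound 3 to compound 4 (0.07 log units; within the scatter). For compound 4 the estimated value is 1000 nM, with an expected range of 450 nM to 2200 nM.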

Compound 4, half-maximal inhibitory concentration: 1760 nM
The estimate for compound 4 lay 1.8-fold (0.25 log units) below the measured number; measured number inside the range.
By their numbers in this assay, from the lowest: compounds 1, 3, 4 and 2 (each within the scatter of the next, the first and the last beyond it).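

In this assay, methoxy on this carbon cannot be told apart from either halogen, with a 1.5-fold higher number from compound 3 to compound 4 (0.18 log units; within the scatter) and a 1.6-fold lower number from compound 2 to compound 4 (0.21 log units; within the scatter), even though chloro and fluoro on the same carbon do differ beyond the scatter. Within the data shown here, at a different aromatic carbon, the one that separates compound 1 from compound 4, chloro in place of fluoro gives a 1.8-fold higher number from compound 1 to compound 4 (0.26 log units; within the scatter). The same swap therefore does not give the same result in both settings, so a step measured on one core cannot simply be carried over to another: the same change on two cores in this assay, a 2.4-fold lower number (0.38 log units; beyond the scatter) from compound 2 to compound 3 and a 1.8-fold higher number (0.26 log units; within the scatter) from compound 1 to compound 4, 4.4-fold (0.64 log units) apart, beyond the scatter of two such steps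

Still open, as far as these compounds go, is whether an amine or a carboxylic acid on this carbon would move the number beyond the scatter. The compounds shown also cannot explain why the swap from fluoro to chloro differs between the two cores.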